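Replacing the ethylphenyl group with a thiazole

This account rests on a few compounds, and the source may have more. Where it says the series, first, only, none or still open, it means among the compounds named here.

Measured in a functional assay on A549 cells (Homo sapiens) for cytotoxicity; a lower number here means that less compound is needed, a higher number that more compound is needed for the effect:
- compound 1 `COC1=C(C)C(=O)/C(=C(O)/C=C/c2ccc(F)cc2)C(=O)C1(C)C`: 3.3 ug/mL
- compound 2 `CCc1ccc(/C=C/C(O)=C2/C(=O)C(C)=C(OC)C(C)(C)C2=O)cc1`: 6.1 ug/mL

Among the measured compounds shown here, compound 2 stands at 6.1 ug/mL and cannot be told apart from compound 1, since the only measured step (a 1.8-fold higher number from compound 1 to compound 2 (0.27 log units; within the scatter)) lies within the usual scatter of repeat measurements. Compound 3 `COC1=C(C)C(=O)/C(=C(O)/C=C/c2nccs2)C(=O)C1(C)C` keeps the shared core but changes the group at the end of the chain (1,3-thiazol-2-yl in place of 4-ethylphenyl on a double-bonded chain carbon bound to a double-bonded chain carbon). Here, 1,3-thiazol-2-yl stands in place of 4-ethylphenyl on a double-bonded chain carbon bound to a double-bonded chain carbon. The measured step swapped only ethyl for fluoro on an aromatic carbon, so it is a weak guide to replacing the whole ring. For the measured compounds named here, no measured compound carries a thiazole. No step beyond the scatter is therefore expected in this assay, in either direction, though the uncertainty is wide. The expected step is a 1.0-fold lower number from compound 2 to compound 3 (0.01 log units; within the scatter). The estimated value for compound 3 is 6 ug/mL, with an expected range of 2 ug/mL to 18 ug/mL.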

Compound 3, concentration for half-maximal effect: 3.5 ug/mL
Beside the measured number, compound 3's estimate is 1.7-fold (0.23 log units) above it, and the stated range covers the measured number.
By their numbers in this assay, from the lowest: compounds 1, 3 and 2 (each within the scatter of the next).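

Earlier, only a substituent on the aromatic ring had changed; here the whole ring at the end of the chain is exchanged, and in this assay the result still lies within the scatter for both comparisons: there is a 1.7-fold lower number from compound 2 to compound 3 (0.24 log units; within the scatter), and there is a 1.1-fold higher number from compound 1 to compound 3 (0.03 log units; within the scatter). The entering 1,3-thiazol-2-yl has fewer heavy atoms than 4-ethylphenyl and brings hydrogen-bond acceptors that 4-ethylphenyl lacks, yet neither difference separates the compounds in this assay. This position on a double-bonded chain carbon bound to a double-bonded chain carbon therefore accepts both a six-membered carbon ring and a five-membered ring with hetero atoms without a readable shift.

From the compounds shown here alone, it remains open whether an amine, a carboxylic acid or a simple methyl group in place of the ring would also leave the number within the scatter. No measurement shown here bears on what lies behind this result.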